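The source may report more compounds than this note shows. Statements on the series, on what has been measured and on what is new or still open speak of the compounds shown alone.

Compound 1 `CC(C)c1noc(N2CCC(Oc3cc(N4CCc5cc(N6CC(O)CCC6=O)ccc54)ncn3)CC2)n1` gives 2.6 in a physicochemical assay for lipophilicity, measured as octanol-water partition, at pH 7.4; a lower number here means a more polar compound, a higher number a more lipophilic compound. Compound 2 `CC(C)c1noc(N2CCC(Oc3cc(N4CCc5cc(N6CCCS6(=O)=O)ccc54)ncn3)CC2)n1` gives 3.2 in this assay, the higher of the two numbers, the step being a number 0.60 log units higher from compound 1 to compound 2 (beyond the scatter). Compound 3 `CC(C)c1noc(N2CCC(Oc3cc(N4CCc5cc(S(C)(=O)=O)ccc54)ncn3)CC2)n1` differs from compound 2 by a group of 4 heavy atoms (1 carbon, 2 oxygen, 1 sulfur; no ring) in place of a group of 7 heavy atoms (3 carbon, 1 nitrogen, 2 oxygen, 1 sulfur; one five-membered non-aromatic ring with 2 hetero atoms), on an aromatic carbon. Among the compounds with values here, no measured step covers the entering methylsulfonyl; the one step available, from compound 1 to compound 2, set the leaving ring against a different ring and was modest. With fewer heavy atoms entering than leaving, a downward step smaller than that one is expected, a number 0.40 log units lower from compound 2 to compound 3 (beyond the scatter). Compound 3 is therefore estimated at 2.8, within 2.3 to 3.3.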

Compound 3, distribution coefficient: 3.1
The estimate for compound 3 lay 0.30 log units below the measured number, within the range that was stated.
By their numbers in this assay, from the lowest: compound 1; then compounds 3 and 2 (each within the scatter of the next).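

Methylsulfonyl in place of the five-membered ring on this aromatic carbon gives a number 0.10 log units lower from compound 2 to compound 3 (within the scatter) in this assay, so this change does not separate the two groups, although fewer heavy atoms enter than leave. Against 5-hydroxy-2-oxopiperidin-1-yl, methylsulfonyl gives a number 0.50 log units higher from compound 1 to compound 3 (beyond the scatter), so a group without a ring at this position also stands apart from compound 1. Nothing on hand accounts for either step.

Open, on these data alone, is where an amine or a carboxylic acid at this aromatic carbon would fall in this assay. Also open, as far as these compounds go, is whether ethylsulfonyl, with a longer chain on the sulfur, would stay within the scatter of methylsulfonyl.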